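The source may report more compounds than this note shows. Statements on the series, on what has been measured and on what is new or still open speak of the compounds shown alone.

Measured so far:
Compound 1, `CC/C(=C(/c1ccc(/C=C/C(=O)O)cc1)c1ccc2[nH]ncc2c1)c1ccccc1`, in a functional assay on MCF7 cells (Homo sapiens) for antiproliferative activity, read by CellTiter-Glo, with a stated time of 5 days; a lower number here means a stronger inhibitor, a higher number a weaker inhibitor: compound 1 gives 7.2 nM.
Compound 2, `CC/C(=C(/c1ccc(/C=C/C(=O)O)cc1)c1ccn2nncc2c1)c1ccccc1`: in this assay compound 2 gives only a limit, > 500 nM.
Compound 3, `CC/C(=C(/c1ccc(/C=C/C(=O)O)cc1)c1ccc2nncn2c1)c1ccccc1`: in this assay compound 3 likewise gives only a limit, > 500 nM.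

For the measured compounds named here, compound 1 stands as the only compound of the three with a number in this assay; the other two results sit at a limit, (the limit of > 500 nM in this assay, at which 2 of the 3 values shown sit).

Compound 4, `CC/C(=C(/c1ccc(/C=C/C(=O)O)cc1)c1ccc2sc(C)nc2c1)c1ccccc1`, differs from compound 1 in one place: 2-methyl-1,3-benzothiazol-5-yl in place of 1H-indazol-5-yl on a double-bonded chain carbon bound to an aromatic carbon and a double-bonded chain carbon. The steps measured so far both replace the same group on the same chain carbon, and both go the same way: an at least 69-fold higher number from compound 1 to compound 2 (1.84 log units; beyond the scatter) and an at least 69-fold higher number from compound 1 to compound 3 (1.84 log units; beyond the scatter). Between the two limits the step that the two limits leave unreadable from compound 2 to compound 3. Those two changes swap the indazole for groups in which the six-membered ring also gains a hetero atom, whereas the change to compound 4 keeps one six-membered aromatic ring of carbon only and trades the one hydrogen-bond donor for a second acceptor and a sulfur. The measured steps thus warn of a loss, but a weaker analogy than a direct repeat.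

For compound 4 a weaker result than compound 1 is therefore expected, with an 8.3-fold higher number from compound 1 to compound 4 (0.92 log units; beyond the scatter), though a smaller step than the two measured ones. The estimate for compound 4 in this assay is 60 nM, within a range of 10 nM to 600 nM.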

Compound 4, half-maximal inhibitory concentration: > 500 nM
Compound 4 gave a limit, no number; the forecaster's own chance of this, stated with the estimate: 25%; middle value at least 8.3-fold (0.92 log units) away from the limit.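

With the six-membered aromatic ring of carbon only kept, the change to 2-methyl-1,3-benzothiazol-5-yl on this chain carbon still brings an at least 69-fold higher number from compound 1 to compound 4 (1.84 log units; beyond the scatter). In this assay compound 4 gives only a limit, > 500 nM. A hetero atom gained in the six-membered ring is therefore not required for a large loss at this place, and 1H-indazol-5-yl remains the only group shown here that gives a number rather than a limit: the limit of > 500 nM in this assay, at which 3 of the 4 values shown sit.

The steps among compound 2, compound 3 and compound 4 cannot be read, so these three cannot be ranked against one another. The change to compound 4 also removes the hydrogen-bond donor and brings in sulfur and a methyl group together, so the compounds shown do not tell which of these accounts for the loss, a question that a 1,3-benzothiazol-5-yl group without the methyl, or an indazole carrying a methyl on its ring nitrogen, would help to separate.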